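Swapping a Methoxymethyl for Cyclobutyl on the Alkene Carbon

This account rests on a few compounds, and the source may have more. Where it says the series, first, only, none or still open, it means among the compounds named here.

Within the data shown here, compound 1 `COC/C(=C(/c1ccc(/C=C/C(=O)O)cc1)c1ccc2[nH]ncc2c1)c1ccccc1` holds the only numeric value in a functional assay on MCF7 cells (Homo sapiens) for cytotoxicity, read by CellTiter-Glo, with a stated time of 5 days; on this read-out lower numbers stand for stronger inhibition and higher numbers for weaker inhibition: compound 1 gives 88 nM. Compound 2 `O=C(O)/C=C/c1ccc(/C(=C(/CCO)c2ccccc2)c2ccc3[nH]ncc3c2)cc1` reaches only a limit of the assay, > 1000 nM. Among the measured compounds shown here, the one measured step, an at least 11-fold higher number from compound 1 to compound 2 (1.05 log units; beyond the scatter), sits at that limit (the limit of > 1000 nM in this assay, at which 1 of the 2 values shown sits). Compound 3 `O=C(O)/C=C/c1ccc(/C(=C(\c2ccccc2)C2CCC2)c2ccc3[nH]ncc3c2)cc1` differs from compound 1 by cyclobutyl in place of methoxymethyl on a double-bonded chain carbon bound to an aromatic carbon and a double-bonded chain carbon. For the measured compounds named here, no measured step changes that same carbon, yet the large loss seen on the chain in compound 2 suggests this region tolerates little change, so a loss beyond the scatter is expected for compound 3. Compound 3 is estimated at 250 nM, between 70 nM and 900 nM, an expected step of a 2.8-fold higher number from compound 1 to compound 3 (0.45 log units; beyond the scatter).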

Compound 3, half-maximal inhibitory concentration: 1.4 nM
Compound 3: middle estimate off by 180-fold (2.25 log units), on the high side; the measured number lies below the stated range.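

This position does more than lose activity when changed: cyclobutyl in place of methoxymethyl gives a 63-fold lower number from compound 1 to compound 3 (1.80 log units; beyond the scatter), so a carbon-only ring can bring a large gain here. Cyclobutyl in place of 2-hydroxyethyl gives an at least 710-fold lower number from compound 2 to compound 3 (2.85 log units; beyond the scatter). That step starts from compound 2, whose value is a limit, so its size is only a bound: the limit of > 1000 nM in this assay, at which 1 of the 3 values shown sits.

The compounds shown leave open whether the gain needs a four-membered ring. A cyclopropyl or cyclopentyl ring, or an open isopropyl chain, on this carbon could match cyclobutyl or fall short.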